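From Isobutyl to Benzyl in a Long-Lived Series

The source may hold more compounds than are shown below. What is called first, only, known or untested is meant among the compounds shown, and "the series" means these compounds.

Of the compounds shown here, three sharing one core have been tested in an ADME assay on a cell-free system (plasma, Homo sapiens) for pharmacokinetics; on this read-out lower numbers stand for a shorter-lived compound and higher numbers for a longer-lived compound. For the measured compounds named here, compound 2 `CCOc1cc(NC(=O)C2(NC(=O)c3ccc4c(C5CCCC5)c(-c5ncc(Cl)cn5)n(C)c4c3)CCC2)ccc1/C=C/C(=O)OCC(C)C` gives 6.18 h, the only exact number among them. Compound 1 `CCOC(=O)/C=C/c1ccc(NC(=O)C2(NC(=O)c3ccc4c(C5CCCC5)c(-c5ncc(Cl)cn5)n(C)c4c3)CCC2)cc1OCC` is reported as > 5 h, which is a limit and not a number. Compound 3 `CCOc1cc(NC(=O)C2(NC(=O)c3ccc4c(C5CCCC5)c(-c5ncc(Cl)cn5)n(C)c4c3)CCC2)ccc1/C=C/C(=O)OCC(Cl)(Cl)Cl` is reported as > 5 h, also a limit. The rest of the picture therefore rests on (the limit of > 5 h in this assay, at which 2 of the 3 values shown sit).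

Compound 4 `CCOc1cc(NC(=O)C2(NC(=O)c3ccc4c(C5CCCC5)c(-c5ncc(Cl)cn5)n(C)c4c3)CCC2)ccc1/C=C/C(=O)OCc1ccccc1` is still unmeasured. It differs from compound 2 at one place: phenyl in place of isopropyl on a saturated chain carbon bound to an oxygen next to a carbonyl group. Seen one bond further out, isobutoxycarbonyl becomes benzyloxycarbonyl.

Going by the values given here, three measured steps touch this same place: a step that the limit leaves unreadable from compound 1 to compound 2, a step that the two limits leave unreadable from compound 1 to compound 3 and a step that the limit leaves unreadable from compound 2 to compound 3. None has a readable size, and none of the three compounds has given a short-lived result. With compound 2 at 6.18 h as the anchor, no step beyond the usual scatter is expected in this assay, in either direction. The expected change is a 1.0-fold lower number from compound 2 to compound 4 (0.01 log units; within the scatter). For compound 4 the estimated value is 6 h, within an expected range of 3 h to 12 h, though the result may arrive only as a limit.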

Compound 4, half-life: > 5 h
Compound 4 ended at the assay's limit; the forecaster's own chance of this, stated with the estimate: 45%; the middle value lies beyond the limit too.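

In this assay compound 4 gives > 5 h, which is a limit and not a number. For the compounds shown here, no step from compound 1, compound 2 or compound 3 to compound 4 can be read, and the picture still rests on one thing: the limit of > 5 h in this assay, at which 3 of the 4 values shown sit. The compounds shown leave open whether these four groups differ in half-life at all.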